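Swapping chloro for methoxy on a second porcupine inhibitor core

The source may report more compounds than this note shows. Statements on the series, on what has been measured and on what is new or still open speak of the compounds shown alone.

Of the compounds shown here, three have so far been measured in an assay on L cells for inhibition of Protein-serine O-palmitoleoyltransferase porcupine (Mus musculus), read by reporter gene assay, with a stated time of 24 h; a higher number here means that more compound is needed for the effect, a lower number that less compound is needed. Compound 1, `O=C(CSc1nc2c(c(=O)n1-c1ccccc1)SCC2)Nc1nc2ccc(Cl)cc2s1`, gives 40 nM in this assay. Compound 3, `COc1ccc2nc(NC(=O)CSc3nc4c(c(=O)n3-c3ccccc3)SCC4)sc2c1`, gives 40 nM in this assay. The two share one core and differ only in methoxy in place of chloro on an aromatic carbon, and the result was no change at the digits printed from compound 1 to compound 3 (within the scatter).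

Compound 2, `COc1ccc(-n2nc(C(=O)NCC(=O)Nc3nc4ccc(Cl)cc4s3)c3ccccc3c2=O)cc1`, is built on a different core; how the two cores differ is not broken down here. In this assay compound 2 gives 15 nM, the lowest of the three numbers, and its gap to each of compound 1 and compound 3 lies beyond the scatter.

Compound 4, `COc1ccc(-n2nc(C(=O)NCC(=O)Nc3nc4ccc(OC)cc4s3)c3ccccc3c2=O)cc1`, has not yet been measured. It differs from compound 2 in methoxy in place of chloro on an aromatic carbon, the same change that turns compound 1 into compound 3, so the 6-chloro-1,3-benzothiazol-2-yl amide of compound 2 becomes a 6-methoxy-1,3-benzothiazol-2-yl amide. The change has now been made twice among these compounds, once on each core.

The step from compound 2 to compound 4 in this assay is expected to be no change at the digits printed from compound 2 to compound 4 (within the scatter). Within the data shown here, this expectation rests on the single earlier instance, no change at the digits printed from compound 1 to compound 3 (within the scatter), and on nothing else, since no other data on the second core are available. For compound 4 the expected value in this assay is therefore 15 nM, with a range from 7 nM to 35 nM.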

Compound 4, half-maximal effective concentration: 60 nM
Compound 4: the middle estimate sits 4.0-fold (0.60 log units) below what was measured, and the stated range ends below it.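

In this assay, replacing chloro with methoxy on the core of compound 2 gave a 4.0-fold higher number from compound 2 to compound 4 (0.60 log units; beyond the scatter), so on this core the 6-methoxy-1,3-benzothiazol-2-yl amide does not match the 6-chloro-1,3-benzothiazol-2-yl amide. The same replacement therefore did not carry the same size of step from one core to the other: the same change on two cores in this assay, no change at the digits printed (within the scatter) from compound 1 to compound 3 and a 4.0-fold higher number (0.60 log units; beyond the scatter) from compound 2 to compound 4, 4.0-fold (0.60 log units) apart, beyond the scatter of two such steps

This shows that, among these four compounds, the step measured on one core cannot simply be transferred to the other, but with only one pair on each core it does not show which part of the cores sets the difference, nor whether either step is typical of its core.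

The compounds shown leave open how other groups at this place on the benzothiazole, such as fluoro, methyl or a nitrile, or hydrogen in place of any substituent, would behave on each of the two cores. They also leave open whether a change elsewhere, such as a longer chain between the amide groups or an amine on the phenyl ring, would depend on the core in the same way.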